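Swapping the aryl amide for a benzothiazole amide

The compounds below may be only part of what the source reports. "The series", "measured", "known", "first", "only" and "open" are said of these compounds alone.

The measured compounds and their values:
compound 1, `COc1ccc(NC(=O)CCCCCCNC(=O)C(O)(O)C(F)(F)F)cc1`, 4520 nM
compound 2, `O=C(CCCCCCNC(=O)C(O)(O)C(F)(F)F)Nc1ccc(S(F)(F)(F)(F)F)cc1`, 9110 nM
compound 3, `Cc1ccc(S(=O)(=O)Nc2ccc(NC(=O)CCCCCCNC(=O)C(O)(O)C(F)(F)F)cc2)cc1`, 17200 nM

In a functional assay on HCT-116 cells (Homo sapiens) for inhibition, read by colorimetric assay, with a stated time of 3 days (a higher number here means a weaker inhibitor, a lower number a stronger inhibitor), compound 1 gives the lowest of the three numbers. The step of a 2.0-fold higher number from compound 1 to compound 2 (0.30 log units; within the scatter) stays within the scatter, whereas the step of a 3.8-fold higher number from compound 1 to compound 3 (0.58 log units; beyond the scatter) lies beyond it, so compound 1 is set apart from compound 3 only. The step of a 1.9-fold higher number from compound 2 to compound 3 (0.28 log units; within the scatter) is within the scatter.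

Compound 4, `O=C(CCCCCCNC(=O)C(O)(O)C(F)(F)F)Nc1nc2ccccc2s1`, differs from compound 1 as follows: 1,3-benzothiazol-2-yl in place of 4-methoxyphenyl on an amide-type nitrogen. The measured steps, from compound 1 to compound 2 and from compound 1 to compound 3, change only the substituent on the aromatic carbon of the shared core; none of them exchanges the ring that sits on the amide-type nitrogen. They therefore bear on the change only loosely, showing that altering this end of the molecule has moved the number by modest amounts and only upward. Compound 4 is expected to sit near compound 1, with the step of a 1.1-fold higher number from compound 1 to compound 4 (0.04 log units; within the scatter) estimated to lie within or just beyond the scatter in either direction. The estimate for compound 4 in this assay is 5000 nM, with a range from 1500 nM to 17000 nM.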

Compound 4, half-maximal inhibitory concentration: 2370 nM
The estimate for compound 4 lay 2.1-fold (0.32 log units) above the measured number; the measured number falls inside the stated range.
By their numbers in this assay, from the lowest: compounds 4, 1, 2 and 3 (each within the scatter of the next, the first and the last beyond it).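

For the compounds shown here, the exchange of 4-methoxyphenyl for 1,3-benzothiazol-2-yl on the amide-type nitrogen replaces the whole ring at this place, whereas the earlier steps changed only a substituent on the aromatic carbon of the shared core. In this assay, going by these compounds alone, the result is a 1.9-fold lower number from compound 1 to compound 4 (0.28 log units; within the scatter), so this position accepts a group with one more ring, a five-membered aromatic ring with 2 hetero atoms, without a number that can be told apart from that of compound 1; the earlier steps from compound 1 gave only higher numbers, but this one offers no real gain over compound 1 either. Nothing measured here explains why the exchange leaves the number within the scatter.

This single pair cannot separate the contribution of the added ring from that of the nitrogen and sulfur atoms that enter with it. Also open, from the compounds shown here alone, is how the number would respond to an amine or a carboxylic acid on the 1,3-benzothiazol-2-yl group, or to a longer chain between the amide and the hydrated trifluoroacetamide end of the molecule.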